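This account rests on a few compounds, and the source may have more. Where it says the series, first, only, none or still open, it means among the compounds named here.

Measured compounds and their results in a functional assay on BJAB cells (Homo sapiens) for antiproliferative activity, with a stated time of 4 days; a higher number here means that more compound is needed for the effect, a lower number that less compound is needed:

Compound 1, `Cc1ccccc1-c1c(C)nn(-c2nc(-c3ccc(Cl)c(Cl)c3)c(SC(C)C)s2)c1C(=O)O`, gives 5500 nM.
Compound 2, `Cc1nn(-c2nc(-c3ccc(Cl)c(Cl)c3)c(SC(C)C)s2)c(C(=O)O)c1-c1cccc(Cl)c1C`, gives 5100 nM.
Compound 3, `Cc1cc(-c2c(C)nn(-c3nc(-c4ccc(Cl)c(Cl)c4)c(SC(C)C)s3)c2C(=O)O)cc(C)n1`, gives 580 nM.

Compound 3 has the lowest number of the three; its nearest neighbour is compound 2, from which it is separated by a step beyond the scatter, and compound 1 lies slightly further off. The two steps leading to it, a 9.5-fold lower number from compound 1 to compound 3 (0.98 log units; beyond the scatter) and an 8.8-fold lower number from compound 2 to compound 3 (0.94 log units; beyond the scatter), are both modest and both turn on the same site: the aromatic carbon that carries the aryl group on the five-membered ring with two nitrogens. The step of a 1.1-fold lower number from compound 1 to compound 2 (0.03 log units; within the scatter), by contrast, lies within the scatter.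

Compound 4, `Cc1nn(-c2nc(-c3ccc(Cl)c(Cl)c3)c(SC(C)C)s2)c(C(=O)O)c1-c1cc(C#N)cc(C(F)(F)F)c1`, has not yet been measured in this assay. It differs from compound 3 in one place: 3-cyano-5-(trifluoromethyl)phenyl in place of 2,6-dimethylpyridin-4-yl on an aromatic carbon. The group that enters is larger and again a carbon-only ring, like those of compound 1 and compound 2, yet it keeps one hydrogen-bond acceptor, as the 2,6-dimethylpyridin-4-yl of compound 3 does. The bearing steps show that exchanging this aryl group moves the number modestly, so a step of similar size upward is expected, with wide uncertainty: a 2.6-fold higher number from compound 3 to compound 4 (0.41 log units; beyond the scatter). Compound 4 is therefore estimated at 1500 nM, between 400 nM and 6000 nM.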

Compound 4, half-maximal effective concentration: 3600 nM
For compound 4 the middle estimate is 2.4-fold (0.38 log units) below the measured one, within the range that was stated.
By their numbers in this assay, from the lowest: compound 3; then compounds 4, 2 and 1 (each within the scatter of the next).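

In this assay, replacing the 2,6-dimethylpyridin-4-yl of compound 3 with 3-cyano-5-(trifluoromethyl)phenyl gives a 6.2-fold higher number from compound 3 to compound 4 (0.79 log units; beyond the scatter) and so gives up most of the gain seen with compound 3, even though the entering group has the same count of one hydrogen-bond acceptor. The new group, with 12 heavy atoms and a nitrile and a trifluoromethyl on its ring, does not separate compound 4 from the other two compounds with carbon-only rings: the comparison gives a 1.4-fold lower number from compound 2 to compound 4 (0.15 log units; within the scatter) and also a 1.5-fold lower number from compound 1 to compound 4 (0.18 log units; within the scatter) and both steps lie within the scatter. At this aromatic carbon of the five-membered ring, three quite differently substituted phenyl groups therefore cannot be told apart, and among these four compounds only the ring with a nitrogen, in compound 3, stands apart.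

From the compounds shown here alone, whether that ring nitrogen or the two methyl groups of compound 3 matter more stays open, as does the result for an unsubstituted pyridin-4-yl, a pyrimidine ring or a phenyl ring carrying an amine. No measurement at hand bears on what lies behind the difference between compound 3 and the others.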